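This account rests on a few compounds, and the source may have more. Where it says the series, first, only, none or still open, it means among the compounds named here.

Of the compounds shown here, three with a shared core have been measured in an assay on cells for inhibition of thyroid peroxidase (Homo sapiens), with stated times of 10 min and 15 min; a higher number here means a weaker inhibitor, a lower number a stronger inhibitor. Compound 1 `Nc1cc(Cc2ccn(-c3ccc(F)cc3)n2)c2nn[nH]c2n1` gives 700 nM in this assay. Compound 2 `Nc1cc(Cc2ccn(Cc3ccc4cnccc4c3)n2)c2nn[nH]c2n1` gives 1800 nM in this assay, and compound 3 `Nc1cc(Cc2ccn(Cc3ccc4c(c3)CCNC4)n2)c2nn[nH]c2n1` gives 6700 nM in this assay. Compound 1 therefore carries the lowest number of the three, and the gaps to compound 2 and to compound 3 both lie beyond the usual scatter, so it is the strongest inhibitor among them.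

Compound 4 `Nc1cc(Cc2ccn(-c3ccccc3)n2)c2nn[nH]c2n1` has not yet been measured. It differs from compound 1 in a single place: hydrogen in place of fluoro on an aromatic carbon. Going by the values given here, no pair of measured compounds shows this particular change, so there is no measured step to lean on; the expectation rests on the small size of the change alone.

The step from compound 1 to compound 4 in this assay is expected to be a 1.3-fold higher number from compound 1 to compound 4 (0.11 log units; within the scatter), which is no more than the scatter of repeated measurements. For compound 4 the estimate in this assay is 900 nM, with a likely range from 400 nM to 2000 nM.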

Compound 4, half-maximal inhibitory concentration: 640 nM
Estimate against measurement, compound 4: 1.4-fold (0.15 log units) above; low and high end bracket the measured number.
By their numbers in this assay, from the lowest: compounds 4 and 1 (each within the scatter of the next); then compound 2; then compound 3.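

Going from 4-fluorophenyl to phenyl gives a 1.1-fold lower number from compound 1 to compound 4 (0.04 log units; within the scatter) in this assay and provides the first measured step at this position. Compound 1 and compound 4 cannot be told apart in this assay, so the inhibition seen for compound 1 does not depend on the fluoro group on this aromatic carbon, para to a large group. Nothing available here explains why exchanging fluoro for hydrogen leaves the two numbers within the scatter of each other.

As far as these compounds go, this single pair compares only hydrogen and fluoro, so it remains open whether a methoxy group, a trifluoromethyl group or an amine on the same carbon would also leave the number within the scatter. It also cannot tell whether the same exchange would read alike elsewhere on the phenyl ring.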